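The source may hold more compounds than are shown below. What is called first, only, known or untested is meant among the compounds shown, and "the series" means these compounds.

Among the compounds with values here, compound 1 `COc1ccc(/C=N/NC(=S)NC(C)(C)[C@H]2CC=C(C)CC2)cc1` is the only member of this set to give a numerical result: in a functional assay on 786-0 cells (Homo sapiens) for inhibition, read by sulforhodamine B assay, with a stated time of 48 h (a higher number here means a weaker inhibitor of growth, a lower number a stronger inhibitor of growth), compound 1 gives 8900 nM. Compound 2 `CC1=CC[C@H](C(C)(C)NC(=S)N/N=C/c2ccc(O)cc2)CC1` gives > 100000 nM in this assay, which is a limit of the assay and not a number. Compound 3 `CC1=CC[C@H](C(C)(C)NC(=S)N/N=C/c2ccc(F)cc2)CC1` likewise gives > 100000 nM in this assay, again a limit rather than a number. The two readable steps are both large: an at least 11-fold higher number from compound 1 to compound 2 (1.05 log units; beyond the scatter) and an at least 11-fold higher number from compound 1 to compound 3 (1.05 log units; beyond the scatter), while a step that the two limits leave unreadable from compound 2 to compound 3. Thus compound 3 stands at the limit of > 100000 nM in this assay, at which 2 of the 3 values shown sit, and nothing in the data separates it from compound 2.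

Compound 4 `CC1=CC[C@H](C(C)(C)NC(=S)N/N=C/c2ccccc2Cl)CC1` differs from compound 3 by 2-chlorophenyl in place of 4-fluorophenyl on a carbon with a double bond to nitrogen. Within the data shown here, no measured step swaps one halogen-bearing phenyl for another, so the pair of compounds 2 and 3 is the closest guide, and it is unreadable. What the readable steps do show is that each departure from the methoxy-bearing phenyl of compound 1 sends the value to the limit, and compound 4 departs from it further still. The step of an at least 1.2-fold lower number from compound 3 to compound 4 (0.09 log units; that floor lies within the scatter) is therefore expected to be small or unreadable, with compound 4 most likely reported as a limit once more. For compound 4 the estimate in this assay is 80000 nM, with a range from 15000 nM to 200000 nM.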

Compound 4, concentration for 50% growth inhibition: 85500 nM
Compound 4: middle estimate off by 1.1-fold (0.03 log units), on the low side, within the range that was stated.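

Within the data shown here, with 2-chlorophenyl on the carbon with a double bond to nitrogen, the loss from replacing the 4-methoxyphenyl of compound 1 in this assay can for the first time be sized rather than merely bounded; the result is a 9.6-fold higher number from compound 1 to compound 4 (0.98 log units; beyond the scatter). Compound 1 remains the strongest inhibitor of growth of the four, since its steps to all three other compounds are printed as beyond the scatter. Against the other two compounds the result yields only floors, an at least 1.1-fold lower number from compound 3 to compound 4 (0.06 log units; that floor lies within the scatter) and an at least 1.1-fold lower number from compound 2 to compound 4 (0.06 log units; that floor lies within the scatter), and compound 4 cannot be ordered against either, because each of them is known only as a limit of the assay: the limit of > 100000 nM in this assay, at which 2 of the 4 values shown sit.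

The change from 4-fluorophenyl to 2-chlorophenyl alters both the halogen and its place on the ring, so the compounds shown leave open which of the two goes with the readable value, a question that 4-chlorophenyl and 2-fluorophenyl groups would separate. Also open, from the compounds shown here alone, is whether a 4-ethoxyphenyl or 4-dimethylaminophenyl group on this carbon would come close to the 4-methoxyphenyl of compound 1.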